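The compounds below may be only part of what the source reports. "The series", "measured", "known", "first", "only" and "open" are said of these compounds alone.

Measured so far:
compound 1 `CCCN(CCC)Cc1ccc(Cl)c(-c2ccccc2OC)c1` — > 10000 nM
compound 2 `CCNCc1ccc(Cl)c(-c2ccccc2OC)c1` — 1800 nM

In an assay on isolated protein for binding affinity to 5-hydroxytryptamine receptor 5A (Homo sapiens) (on this read-out higher numbers stand for weaker inhibition and lower numbers for stronger inhibition), compound 1 gives only a limit of the assay, > 10000 nM (the limit of > 10000 nM in this assay, at which 1 of the 2 values shown sits). Compound 2 gives 1800 nM in this assay. Among the compounds with values here, one measured step bears on the change considered here: an at least 5.5-fold lower number from compound 1 to compound 2 (0.74 log units; beyond the scatter). Compound 3 `COc1ccccc1-c1cc(CN(C)C)ccc1Cl` differs from compound 1 by dimethylamino in place of dipropylamino on a saturated chain carbon bound to an aromatic carbon, a change of the same kind as in that step. A lower number of comparable size is therefore expected, though compound 1 stands at a limit and the true gap may be larger. Compound 3 is expected at 2500 nM (range 800 nM to 10000 nM), an expected step of an at least 4.0-fold lower number from compound 1 to compound 3 (0.60 log units; beyond the scatter).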

Compound 3, inhibition constant: 220 nM
Beside the measured number, compound 3's estimate is 11-fold (1.06 log units) above it, and the stated range ends above it.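

Working notes: on the saturated chain carbon bound to an aromatic carbon, dimethylamino in place of dipropylamino gives an at least 45-fold lower number from compound 1 to compound 3 (1.65 log units; beyond the scatter). That step has no fixed size, as compound 1 stands at a limit of the assay: the limit of > 10000 nM in this assay, at which 1 of the 3 values shown sits.

Dimethylamino in place of ethylamino gives an 8.2-fold lower number from compound 2 to compound 3 (0.91 log units; beyond the scatter), so the gain at this position does not stop at ethylamino, and the two small amino groups do not read alike.

Open: whether methylamino, a primary amine or a pyrrolidine ring at this position would give a lower number still. Also open, from the compounds shown here alone, is whether dimethylamino keeps this advantage on a changed core.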